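Aryl Swap on a Triazole Arm: Expecting Another Assay Limit

The source may report more compounds than this note shows. Statements on the series, on what has been measured and on what is new or still open speak of the compounds shown alone.

Compound 1, `N#CC1=C(N)Oc2c(c3nc4ccccc4nc3c3ccccc23)C12C(=O)N(Cc1cnnn1-c1cccc(Br)c1)c1ccccc12`, gives in a functional assay on HepG2 cells (Homo sapiens) for antiproliferative activity, read by MTT assay, with a stated time of 48 h (on this read-out higher numbers stand for weaker inhibition and lower numbers for stronger inhibition), only a limit, > 50000 nM.
Compound 2, `COc1ccc(-n2nncc2CN2C(=O)C3(C(C#N)=C(N)Oc4c3c3nc5ccccc5nc3c3ccccc43)c3ccccc32)cc1`, likewise gives only a limit, > 50000 nM.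
Compound 3, `N#CC1=C(N)Oc2c(c3nc4ccccc4nc3c3ccccc23)C12C(=O)N(Cc1cnnn1-c1ccc(N)cc1)c1ccccc12`, also gives only a limit, > 50000 nM.

Compound 3 therefore stands nowhere in particular on the numbers shown: its value is a limit of this assay, not a measured number, and it shares that position with the other two compounds, since (the limit of > 50000 nM in this assay, at which 3 of the 3 values shown sit). The three single-point changes among the measured compounds, a step that the two limits leave unreadable from compound 1 to compound 2, a step that the two limits leave unreadable from compound 1 to compound 3 and a step that the two limits leave unreadable from compound 2 to compound 3, are all unreadable for the same reason: both ends sit at the limit, so no size can be assigned.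

Compound 4, `Cc1cc(C)cc(-n2nncc2CN2C(=O)C3(C(C#N)=C(N)Oc4c3c3nc5ccccc5nc3c3ccccc43)c3ccccc32)c1`, differs from compound 3 only by 3,5-dimethylphenyl in place of 4-aminophenyl on an aromatic nitrogen. All steps that bear on it are unreadable, so no direction or size can be expected beyond the scatter; the best expectation is that compound 4 also reaches only the limit. The estimated step from the measured compound is a number no higher from compound 3 to compound 4 (the limit leaves the size open). Compound 4 is estimated at 50000 nM, within a range from 25000 nM to 100000 nM.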

Compound 4, half-maximal inhibitory concentration: > 50000 nM
Compound 4: a limit, no number; the forecaster's own chance of this, stated with the estimate: 85%; the middle value lies on the limit itself.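

In this assay compound 4 gives > 50000 nM as well, which is a limit and not a number. Going by these compounds alone, no step from compound 1, compound 2 or compound 3 to compound 4 can be read, because all four sit at the same limit: the limit of > 50000 nM in this assay, at which 4 of the 4 values shown sit. The compounds shown leave open whether any group on this aromatic nitrogen can give a measurable value.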